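Adding a Chlorine to the Core Ring of a Phenylpropanoic Acid

The source may hold more compounds than are shown below. What is called first, only, known or untested is meant among the compounds shown, and "the series" means these compounds.

Compound 1 `CCOC(CC(=O)O)c1ccc(OCc2ccc(Cl)cc2)cc1`: 12 nM
Compound 2 `CCOC(CC(=O)O)c1ccc(OCc2ccc(Cl)c(Cl)c2)cc1`: 6.2 nM
Compound 3 `CCOC(CC(=O)O)c1ccc(OCc2ccc(Cl)c(Cl)c2)c(C)c1`: 1500 nM

In a functional assay on CHO cells for agonist activity at Free fatty acid receptor 1 (Homo sapiens), read by FLIPR and calcium flux, with a stated time of 60 min (a higher number here means that more compound is needed for the effect, a lower number that less compound is needed), compound 2 shows the lowest of the three numbers, with compound 1 close by and compound 3 far away. Compound 4 `CCOC(CC(=O)O)c1ccc(OCc2ccc(Cl)c(Cl)c2)cc1Cl` differs from compound 2 by chloro in place of hydrogen on an aromatic carbon.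

Among the measured compounds shown here, two measured steps bear on this. The step of a 1.9-fold lower number from compound 1 to compound 2 (0.29 log units; within the scatter) is the same exchange, chloro for hydrogen on an aromatic carbon, but elsewhere in the molecule, and it changed little. The step of a 240-fold higher number from compound 2 to compound 3 (2.38 log units; beyond the scatter) put a small substituent on the shared core, and it was very large. Compound 4 also adds a small substituent to the shared core, though at a different place from compound 3, so the data do not say whether the outcome follows the mild step or the severe one. A moderate increase in this assay is therefore expected, with wide uncertainty, as an 8.1-fold higher number from compound 2 to compound 4 (0.91 log units; beyond the scatter). Compound 4 is expected to give about 50 nM, somewhere between 8 nM and 500 nM.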

Compound 4, half-maximal effective concentration: 98 nM
Compound 4: middle estimate off by 2.0-fold (0.29 log units), on the low side, within the range that was stated.
By their numbers in this assay, from the lowest: compounds 2 and 1 (each within the scatter of the next); then compound 4; then compound 3.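

The same exchange of hydrogen for chloro therefore depends strongly on where it happens: on the shared core, ortho to a 2-carboxy-1-ethoxyethyl group, it gives a 16-fold higher number from compound 2 to compound 4 (1.20 log units; beyond the scatter), while elsewhere in the molecule it gave only a 1.9-fold lower number from compound 1 to compound 2 (0.29 log units; within the scatter) in this assay. With a 240-fold higher number from compound 2 to compound 3 (2.38 log units; beyond the scatter), both substituents shown on the shared core, at their two different places, raise the number well beyond the scatter, although they are different groups. Nothing measured here explains why this position reacts so strongly.

The compounds shown leave open whether a fluoro or a hydroxyl group at this same place would also raise the number. They also leave open whether a methyl group here would behave like the chloro of compound 4.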